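A Methoxy Group Added to the Aromatic Ring

The compounds below may be only part of what the source reports. "The series", "measured", "known", "first", "only" and "open" are said of these compounds alone.

Compound 1 `CC(C)(C)OC(=O)/C=C1/C(=O)Nc2ccccc21` is the starting point. In a functional assay on HL-60 cells (Homo sapiens) for cytotoxicity, read by CCK-8 assay, with a stated time of 72 h (a higher number here means a weaker inhibitor, a lower number a stronger inhibitor), compound 1 gives 2450 nM. Among the measured compounds shown here, its one measured neighbour, compound 2 `CN1C(=O)/C(=C/C(=O)OC(C)(C)C)c2ccccc21`, gives 2760 nM, and the step of a 1.1-fold higher number from compound 1 to compound 2 (0.05 log units; within the scatter) shows that methyl in place of hydrogen on the ring nitrogen leaves the read-out essentially unchanged. Among the two numbers so far, compound 1 has the lowest, but the gap to compound 2 lies within the scatter, so no order can be claimed.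

Compound 3 `COc1ccc2c(c1)/C(=C\C(=O)OC(C)(C)C)C(=O)N2` has not been measured. Its change from compound 1 is methoxy in place of hydrogen on an aromatic carbon. For the measured compounds named here, no measured step touches the aromatic ring, so the only step known, which sits elsewhere, offers no direct guide, and there is nothing to suggest a shift beyond the scatter. Compound 3 is therefore expected to give about 2500 nM, within 1200 nM to 5200 nM. That estimate means a step of a 1.0-fold higher number from compound 1 to compound 3 (0.01 log units; within the scatter).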

Compound 3, half-maximal inhibitory concentration: 6190 nM
For compound 3 the middle estimate is 2.5-fold (0.39 log units) below the measured one; measured number outside the range, above it.
By their numbers in this assay, from the lowest: compounds 1 and 2 (each within the scatter of the next); then compound 3.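

Methoxy in place of hydrogen on this aromatic carbon, meta to a fused ring and para to a fused ring, is the first change to the aromatic ring with a measured result in this assay, and it gives a 2.5-fold higher number from compound 1 to compound 3 (0.40 log units; beyond the scatter) for a modest loss of strength. The methyl on the ring nitrogen left the number within the scatter, so this position is the first shown to respond to a substitution, and the response is towards a weaker inhibitor. Nothing measured here indicates why the number rises.

Still open, as far as these compounds go, is whether a different group on this same aromatic carbon, such as fluorine or an amine, would also raise the number. From the compounds shown here alone, it is equally open whether methoxy on another carbon of that ring would do the same.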